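The source may hold more compounds than are shown below. What is called first, only, known or untested is meant among the compounds shown, and "the series" means these compounds.

The measured compounds and their values in a functional assay on MDA-MB-231 cells (Homo sapiens) for cytotoxicity, read by sulforhodamine B assay, tested at 10 uM; a higher number here means more inhibition at the concentration tested (going by the name of the read-out), a lower number less inhibition:

compound 1 `CCCCc1ccc(-c2cc(-c3cn([C@H]4C[C@H](OC(C)=O)[C@@H](COC(C)=O)O4)c(=O)[nH]c3=O)on2)cc1`: 72.2%
compound 2 `CC(=O)OC[C@H]1O[C@@H](n2cc(-c3cc(C)no3)c(=O)[nH]c2=O)C[C@@H]1OC(C)=O`: 106%
compound 3 `CCCc1cc(-c2cn([C@H]3C[C@H](OC(C)=O)[C@@H](COC(C)=O)O3)c(=O)[nH]c2=O)on1`: 102%

Compound 3 stands second highest of the three; its nearest neighbour is compound 2, which lies a number 4 percentage points lower from compound 2 to compound 3 (within the scatter), a gap within the scatter, while compound 1 lies furthest, as a number 29.8 percentage points higher from compound 1 to compound 3 (beyond the scatter) shows. Compound 1 is set apart from the other two also by structure, carrying a 4-butylphenyl group where compound 2 has a methyl and compound 3 a propyl; the steps of a number 33.8 percentage points higher from compound 1 to compound 2 (beyond the scatter) and a number 29.8 percentage points higher from compound 1 to compound 3 (beyond the scatter) both exceed the scatter.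

Compound 4 `CCCCCc1cc(-c2cn([C@H]3C[C@H](OC(C)=O)[C@@H](COC(C)=O)O3)c(=O)[nH]c2=O)on1` is not yet measured. Its difference from compound 3 is ethyl in place of hydrogen on a saturated chain carbon, three bonds along the chain from an aromatic carbon. Within the data shown here, the only measured step of the same kind is the one from compound 2 to compound 3, where lengthening the chain gave a number 4 percentage points lower from compound 2 to compound 3 (within the scatter), a change within the scatter. On that basis the step from compound 3 to compound 4 in this assay is expected to be a number 4 percentage points lower from compound 3 to compound 4 (within the scatter), with no direction beyond the scatter. Compound 4 is therefore estimated at 98%, with a range from 80% to 110%.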

Compound 4, a percentage reported as inhibition, at one concentration (the size of the read-out at that concentration, not a potency): 91.5%
Estimate against measurement, compound 4: 6.5 percentage points above; the measured number falls inside the stated range.
By their numbers in this assay, from the lowest: compound 1; then compound 4; then compounds 3 and 2 (each within the scatter of the next).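

In this assay, lengthening the chain at this position now gives a step that passes the scatter, a number 10.5 percentage points lower from compound 3 to compound 4 (beyond the scatter), whereas the earlier move from methyl to propyl stayed within it. Measured from the methyl end, the full change to pentyl gives a number 14.5 percentage points lower from compound 2 to compound 4 (beyond the scatter), so the three alkyl compounds no longer read as a flat series and the pentyl chain stands apart from the two shorter chains. The pentyl chain still does not bring the number down as far as 4-butylphenyl does, with a number 19.3 percentage points higher from compound 1 to compound 4 (beyond the scatter), so in this small set the 4-butylphenyl group gives the lowest number and the pentyl chain an intermediate one.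

From the compounds shown here alone, whether a longer chain such as octyl would lower the number further, or whether a hydroxyl or an amine at the end of the chain would change it, stays open, as does any comparison with a phenyl group lacking the butyl chain. The data offer no measurement that explains why the number falls along this chain.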